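The source may hold more compounds than are shown below. What is called first, only, known or untested is meant among the compounds shown, and "the series" means these compounds.

Measured in a functional assay (aorta) with Rattus norvegicus as the target; on this read-out higher numbers stand for an effect only at larger amounts of compound and lower numbers for an effect already at smaller amounts:

- Compound 1 `CC(C)(C)C[C@H](N)C(=O)Nc1cc2cc[nH]c(=O)c2cc1Cl`: "not determined" (no result reported)
- Compound 2 `N[C@H](C(=O)Nc1cc2cc[nH]c(=O)c2cc1Cl)C1CCCCC1`: 180 nM
- Compound 3 `CC(C)C[C@H](N)C(=O)Nc1cc2cc[nH]c(=O)c2cc1Cl`: "not determined" (no result reported)

In this assay compound 3 has no single number, only the entry "not determined" (no result reported), and compound 1 shares that fate. The next compound, compound 4 `CC(C)[C@H](N)C(=O)Nc1cc2cc[nH]c(=O)c2cc1Cl`, has not yet been measured. The change is isopropyl in place of isobutyl on a saturated chain carbon bound to an amine nitrogen and a carbonyl carbon. Among the compounds with values here, with no number for compound 3, no step can be anchored there, so no direction is expected and no shift beyond the usual scatter is assumed. Within the data shown here, the only guide is compound 2 at 180 nM. For compound 4 the expected value is 350 nM, with an estimated range from 90 nM to 1400 nM.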

Compound 4, half-maximal effective concentration: 500 nM
Compound 4: middle estimate off by 1.4-fold (0.15 log units), on the low side; low and high end bracket the measured number.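

In this assay, isopropyl in place of cyclohexyl on the saturated chain carbon bound to an amine nitrogen and a carbonyl carbon gives a 2.8-fold higher number from compound 2 to compound 4 (0.44 log units; beyond the scatter), so the group held here changes the read-out. The change from isobutyl to isopropyl cannot be read: compound 3 has no single number. Nothing available explains the step. From the compounds shown here alone, how a phenyl ring or a carboxylic acid at this place would read remains open. So does where isobutyl itself stands against cyclohexyl and isopropyl.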